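From Pyrazole to Pyridine on a Hydrazone Triazine

The compounds below may be only part of what the source reports. "The series", "measured", "known", "first", "only" and "open" are said of these compounds alone.

Two compounds share the hydrazone-bearing core. Compound 1 `NS(=O)(=O)c1ccc(Nc2nc(N/N=C/c3ccc(C(F)(F)F)cc3)nc(Nc3ccccc3)n2)cc1` gives 63800 nM in a functional assay on A498 cells (Homo sapiens) for inhibition, read by sulforhodamine B assay, with a stated time of 48 h (on this read-out higher numbers stand for lower toxicity in this test and lower numbers for higher toxicity in this test), and compound 2 `Cc1nn(-c2ccccc2)cc1/C=N/Nc1nc(Nc2ccccc2)nc(Nc2ccc(S(N)(=O)=O)cc2)n1` gives 6710 nM, the lowest of the two numbers, with a 9.5-fold lower number from compound 1 to compound 2 (0.98 log units; beyond the scatter). Compound 3 `NS(=O)(=O)c1ccc(Nc2nc(N/N=C/c3ccccn3)nc(Nc3ccccc3)n2)cc1` carries pyridin-2-yl in place of 3-methyl-1-phenyl-1H-pyrazol-4-yl on a carbon with a double bond to nitrogen. For the measured compounds named here, only that single step bears on this change, and it concerned a different aryl group, so it guides the expectation only loosely. Compound 3 is expected to give a number near 15000 nM, between 4000 nM and 60000 nM. The expected step is a 2.2-fold higher number from compound 2 to compound 3 (0.35 log units; beyond the scatter), a small rise that may well stay within the scatter.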

Compound 3, concentration lethal to 50% of the cells: 6890 nM
The estimate for compound 3 lay 2.2-fold (0.34 log units) above the measured number, within the range that was stated.
By their numbers in this assay, from the lowest: compounds 2 and 3 (each within the scatter of the next); then compound 1.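

At this carbon, the single ring of pyridin-2-yl and the two rings of 3-methyl-1-phenyl-1H-pyrazol-4-yl cannot be told apart in this assay with a 1.0-fold higher number from compound 2 to compound 3 (0.01 log units; within the scatter) as the step. The lower number of compound 2 therefore does not require the pyrazole or its phenyl ring, as pyridin-2-yl also gives a 9.3-fold lower number from compound 1 to compound 3 (0.97 log units; beyond the scatter) in place of 4-(trifluoromethyl)phenyl. No measurement shown accounts for this result. The compounds shown leave open how this carbon would read with an amine or a carboxylic acid on the aromatic ring.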